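Anilino substitution and cell-growth inhibition in A549 cells

The source may hold more compounds than are shown below. What is called first, only, known or untested is meant among the compounds shown, and "the series" means these compounds.

Compound 1 `CCOC(=O)C1=C(Nc2ccccc2)S/C(=C\c2ccc[nH]2)C1=O` — > 100000 nM
Compound 2 `CCOC(=O)C1=C(Nc2ccccc2Br)S/C(=C\c2ccc[nH]2)C1=O` — 43200 nM

Of the compounds shown here, two sharing one core have been measured in a functional assay on A549 cells (Homo sapiens) for inhibition, read by MTT assay, with a stated time of 72 h; a lower number here means a stronger inhibitor, a higher number a weaker inhibitor. Compound 1 reaches only a limit of the assay, (the limit of > 100000 nM in this assay, at which 1 of the 2 values shown sits). Among the compounds with values here, compound 2 gives 43200 nM, and it holds the only actual number in this assay. Within the data shown here, the one measured step, an at least 2.3-fold lower number from compound 1 to compound 2 (0.36 log units; beyond the scatter), shows that placing a bromine on the aromatic carbon of the anilino ring lowers the number beyond the scatter.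

Compound 3 `CCOC(=O)C1=C(Nc2cccc([N+](=O)[O-])c2)S/C(=C\c2ccc[nH]2)C1=O` is not yet measured. It differs from compound 2 by 3-nitrophenyl in place of 2-bromophenyl on an amine nitrogen. Among the measured compounds shown here, the step from compound 1 to compound 2 is the only one that bears on it, and it concerns a different substituent at a different place on the same ring, so it tells only that decoration of that ring is tolerated. Compound 3 is therefore expected to stay near compound 2, with a 1.0-fold higher number from compound 2 to compound 3 (0.02 log units; within the scatter) lying within the scatter. The estimate for compound 3 in this assay is 45000 nM, between 15000 nM and 100000 nM.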

Compound 3, half-maximal inhibitory concentration: 23900 nM
Compound 3: the middle estimate sits 1.9-fold (0.27 log units) above what was measured; the range from low to high includes it.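

In this assay, the exchange on the amine nitrogen gives a 1.8-fold lower number from compound 2 to compound 3 (0.26 log units; within the scatter), so 3-nitrophenyl and 2-bromophenyl cannot be told apart at this position, and compound 3 joins compound 2 as a second anilino compound with an actual number. The nitro group also gives an at least 4.1-fold lower number from compound 1 to compound 3 (0.62 log units; beyond the scatter), which shows that a second kind of substituent on the ring, not bromo alone, lowers the number beyond the scatter relative to the plain phenyl of compound 1. This step can be read only as a minimum, since compound 1 stands at a limit rather than at a number: the limit of > 100000 nM in this assay, at which 1 of the 3 values shown sits.

The compounds shown leave open whether any group on this ring would do the same, or whether a methoxy group, an amine or a carboxylic acid there would part from bromo and nitro. They also leave open whether bromo and nitro would read the same if each stood elsewhere on the ring, and whether a change outside this ring would move the number further.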